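Swapping a Hydroxy for a Chloro on Compound 1

The source may report more compounds than this note shows. Statements on the series, on what has been measured and on what is new or still open speak of the compounds shown alone.

Compound 1 `CC1(C)[C@H]2CC[C@]1(C)N(Cc1cn(-c3ccccc3O)nn1)C(=O)C2` was tested in a functional assay on SGC-7901 cells (Homo sapiens) for inhibition, read by MTT assay, with a stated time of 24 h (on this read-out higher numbers stand for weaker inhibition and lower numbers for stronger inhibition), where compound 1 gives 410 nM. Among the three measured compounds this is the highest number. Compound 2 `CC1(C)[C@H]2CC[C@]1(C)N(Cc1cn(-c3cccc(O)c3)nn1)C(=O)C2` gives 270 nM, and a 1.5-fold lower number from compound 1 to compound 2 (0.18 log units; within the scatter). Compound 3 `CC1(C)[C@H]2CC[C@]1(C)N(Cc1cn(-c3cccc(Br)c3)nn1)C(=O)C2` gives 120 nM, and a 3.4-fold lower number from compound 1 to compound 3 (0.53 log units; beyond the scatter).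

Compound 4 `CC1(C)[C@H]2CC[C@]1(C)N(Cc1cn(-c3ccccc3Cl)nn1)C(=O)C2` has not yet been measured. It differs from compound 1 in a single place: chloro in place of hydroxy on an aromatic carbon. For the measured compounds named here, the measured step that bears most directly on this change is the one between compound 2 and compound 3, where a halogen likewise replaced a hydroxy on an aromatic carbon, though at a different spot on the ring: a 2.3-fold lower number from compound 2 to compound 3 (0.35 log units; beyond the scatter). The larger step from compound 1 to compound 3 mixes that same swap with a shift of position, so it is a weaker guide. Going by the values given here, no measured pair shows a halogen for hydroxy swap at the exact spot changed here.

A modest step to a lower number is therefore expected in this assay, because a 2.3-fold lower number from compound 2 to compound 3 (0.35 log units; beyond the scatter) points that way. Compound 4 is expected to give 180 nM, with a likely range from 80 nM to 450 nM. That expectation corresponds to a 2.3-fold lower number from compound 1 to compound 4 (0.36 log units; beyond the scatter).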

Compound 4, half-maximal inhibitory concentration: 220 nM
The estimate for compound 4 lay 1.2-fold (0.09 log units) below the measured number; the range from low to high includes it.
By their numbers in this assay, from the lowest: compounds 3, 4, 2 and 1 (each within the scatter of the next, the first and the last beyond it).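

In this assay, for the compounds shown here, compound 4 gives the first direct reading of a halogen for hydroxy swap on the aromatic carbon ortho to a large group, and a 1.9-fold lower number from compound 1 to compound 4 (0.27 log units; within the scatter) shows that this swap cannot be told apart from no change. At this position, then, the hydroxy, counted with a hydrogen-bond donor and acceptor, can give way to a chloro, counted with neither, without a step that exceeds the usual spread of repeated measurements. The 2-chlorophenyl group also cannot be ranked against the two groups on the other compounds, as a 1.8-fold higher number from compound 3 to compound 4 (0.26 log units; within the scatter) and a 1.2-fold lower number from compound 2 to compound 4 (0.09 log units; within the scatter) both stay within the scatter, even though compounds 1 and 3 do differ from each other by more than the scatter. No measurement shown here explains why the hydroxy and chloro compounds read so alike.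

Still open, on these data alone, is how an amine, a methoxy group or a carboxylic acid would read at this same spot on the ring. Also open, as far as these compounds go, is whether a 2-bromophenyl group would read like the 2-chlorophenyl group of compound 4 or like the 3-bromophenyl group of compound 3.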